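The compounds below may be only part of what the source reports. "The series", "measured", "known", "first", "only" and "open" are said of these compounds alone.

Within the data shown here, compound 2 `CC(c1ccc(-c2ccccc2)c(F)c1)c1nnc2n1N=C(c1ccccc1)CS2` gives 6700 nM in a functional assay on Huh-7 cells (Homo sapiens) for inhibition, read by sulforhodamine B assay, with a stated time of 72 h; on this read-out higher numbers stand for weaker inhibition and lower numbers for stronger inhibition; compound 1 `CC(c1ccc(-c2ccccc2)c(F)c1)c1nnc2n1N=C(c1ccc(Cl)cc1Cl)CS2` gives 3700 nM, and the two stand within the scatter of each other, the only measured step being a 1.8-fold higher number from compound 1 to compound 2 (0.26 log units; within the scatter). Compound 3 `CC(c1ccc(-c2ccccc2)c(F)c1)c1nnc2n1N=C(c1ccc(C(F)(F)F)cc1)CS2` differs from compound 2 by trifluoromethyl in place of hydrogen on an aromatic carbon. Among the measured compounds shown here, the one step that bears on this, swapping the ring on the carbon with a double bond to nitrogen, moved the number little, so for compound 3 no step beyond the scatter in this assay is expected. The expected value for compound 3 is 5000 nM, range 2000 nM to 12000 nM. This estimate amounts to a 1.3-fold lower number from compound 2 to compound 3 (0.13 log units; within the scatter).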

Compound 3, half-maximal inhibitory concentration: 9400 nM
For compound 3 the middle estimate is 1.9-fold (0.27 log units) below the measured one; low and high end bracket the measured number.
By their numbers in this assay, from the lowest: compounds 1, 2 and 3 (each within the scatter of the next, the first and the last beyond it).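

Trifluoromethyl on an aromatic carbon para to a large group is tolerated in this assay without a change beyond the scatter (a 1.4-fold higher number from compound 2 to compound 3 (0.15 log units; within the scatter)). The ring on the carbon with a double bond to nitrogen now gives its first step beyond the scatter, a modest one (a 2.5-fold higher number from compound 1 to compound 3 (0.40 log units; beyond the scatter)), so the choice of substituents on this ring can matter, though only between these two rings. Nothing available explains this step.

From the compounds shown here alone, whether an amine, a carboxylic acid or a methoxy group at this ring position would shift the number further remains open.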